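Swapping a fluoro for a formylaminomethyl on the pendant ring

The source may hold more compounds than are shown below. What is called first, only, known or untested is meant among the compounds shown, and "the series" means these compounds.

Measured compounds:
Compound 1, `Cn1nc2c(=O)n(CC3(O)CCN(Cc4ccc(-c5n[nH]c(=O)o5)cc4Cl)CC3)cnc2c1-c1ccc(CN)cc1`: 171 nM
Compound 2, `Cn1nc2c(=O)n(CC3(O)CCN(Cc4ccc(-c5ccco5)cc4Cl)CC3)cnc2c1-c1ccc(F)cc1`: 64.5 nM
Compound 3, `Cn1nc2c(=O)n(CC3(O)CCN(Cc4ccc(-c5ccsc5Cl)cc4Cl)CC3)cnc2c1-c1ccc(CN)cc1`: 453 nM

In an assay on isolated protein for inhibition of ubiquitin carboxyl-terminal hydrolase 7 (Homo sapiens), with stated times of 30 min and 2 h (on this read-out lower numbers stand for stronger inhibition and higher numbers for weaker inhibition), compound 2 stands with the lowest of the three numbers; compound 1 and compound 3 both sit beyond the scatter above it. Within the data shown here, the one measured step, a 2.6-fold higher number from compound 1 to compound 3 (0.42 log units; beyond the scatter), changes a ring on the other side of the shared core and leaves the pendant phenyl untouched, so it says nothing direct about the change now in question.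

Compound 4, `Cn1nc2c(=O)n(CC3(O)CCN(Cc4ccc(-c5ccco5)cc4Cl)CC3)cnc2c1-c1ccc(CNC=O)cc1`, differs from compound 2 only on that pendant phenyl: (formylamino)methyl in place of fluoro on an aromatic carbon. Among the measured compounds shown here, no measured pair isolates this exchange. Compound 1 and compound 3 carry an aminomethyl at the same place and give higher numbers than compound 2, but they also differ elsewhere, so their gap cannot be laid on the pendant group alone. The expected step from compound 2 to compound 4 in this assay is therefore taken as small to modest, tending toward a higher number, a 1.7-fold higher number from compound 2 to compound 4 (0.23 log units; within the scatter). Compound 4 is estimated at 110 nM, between 35 nM and 350 nM.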

Compound 4, half-maximal inhibitory concentration: 20.9 nM
Estimate against measurement, compound 4: 5.3-fold (0.72 log units) above, and the stated range ends above it.
By their numbers in this assay, from the lowest: compound 4; then compound 2; then compound 1; then compound 3.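

In this assay, placing (formylamino)methyl in place of fluoro on an aromatic carbon para to a large group gives a 3.1-fold lower number from compound 2 to compound 4 (0.49 log units; beyond the scatter). Among these compounds, this pair is the first in which only the group at this position changes, and it shows that the position accepts a larger group carrying a hydrogen-bond donor and acceptor with no loss, and in fact with a lower number. Nothing measured here explains the drop.

As far as these compounds go, it remains open which part of the (formylamino)methyl group matters, and a hydroxymethyl or an (acetylamino)methyl at the same place, with everything else kept as in compound 4, would help to separate them. Also open, from the compounds shown here alone, is whether the same exchange would lower the number when the other end of the molecule carries the ring of compound 1 or compound 3.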